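From Ethyl to Prop-1-yn-1-yl on the Sugar Ring

The source may report more compounds than this note shows. Statements on the series, on what has been measured and on what is new or still open speak of the compounds shown alone.

This account concerns a small set of nucleosides tested in a functional assay on Sarcoma-180 cells (Mus musculus) for cytotoxicity; a lower number here means a stronger inhibitor, a higher number a weaker inhibitor. For the measured compounds named here, compound 1, `C#C[C@]1(O)[C@@H](CO)O[C@@H](n2ccc(=O)[nH]c2=O)[C@@H]1O`, is the only compound here with a definite number: in this assay compound 1 gives 13 nM. Compound 2, `CC[C@@]1(O)[C@@H](CO)O[C@@H](n2ccc(N)nc2=O)[C@@H]1O`, yields only a limit of the assay: in this assay compound 2 gives > 30000 nM. Compound 2 therefore stands at the limit of > 30000 nM in this assay, at which 1 of the 2 values shown sits, and nothing finer can be said about where it lies. Compound 3, `CC#C[C@@]1(O)[C@@H](CO)O[C@@H](n2ccc(N)nc2=O)[C@@H]1O`, has not yet been tested. It differs from compound 2 in one place, (prop-1-yn-1-yl in place of ethyl on a saturated ring carbon). Going by the values given here, no step between measured compounds is recorded, so the size of this change cannot be read from the data; the writer expects the step of an at least 15-fold lower number from compound 2 to compound 3 (1.17 log units; beyond the scatter) to be a gain in this assay beyond the usual scatter, while a second limit remains a real possibility. Compound 3 is accordingly estimated at 2000 nM, within a range of 100 nM to 30000 nM.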

Compound 3, half-maximal inhibitory concentration: 13900 nM
Beside the measured number, compound 3's estimate is 7.0-fold (0.84 log units) below it, within the range that was stated.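

In this assay, prop-1-yn-1-yl in place of ethyl on this saturated ring carbon moves the series from a limit to a definite number, giving an at least 2.1-fold lower number from compound 2 to compound 3 (0.33 log units; beyond the scatter). For the compounds shown here, this is the first reading of what a change at this position can do, and it shows that a group with a triple bond here gives a measurable gain over ethyl, although a modest one on what can be read. The true size of the step may be larger, because compound 2 is known only as a limit: the limit of > 30000 nM in this assay, at which 1 of the 3 values shown sits.

The compounds shown leave open whether the gain comes from the triple bond or from the added carbon, a question that a propyl group at this carbon would address. Also open, as far as these compounds go, is how a longer chain or an amine would read here, and whether the gain would carry over to the core of compound 1, which differs from compound 3 in more than one place.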